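Ethyl to benzyl: the step to compound 4

The compounds below may be only part of what the source reports. "The series", "measured", "known", "first", "only" and "open" are said of these compounds alone.

Of the compounds shown here, three sharing one core have been read in a functional assay on SEM cells (Homo sapiens) for cytotoxicity, with a stated time of 72 h; on this read-out higher numbers stand for an effect only at larger amounts of compound and lower numbers for an effect already at smaller amounts. Compound 1 `C=C[C@@](C)(/C=C/c1ccc(O)cc1)CC/C=C(\C)C=O` gives > 36600 nM, which is a limit. Compound 2 `C=C[C@@](C)(/C=C/c1ccc(O)cc1)CC/C=C(\C)CO` gives > 36600 nM, again a limit. Compound 3 `C=C[C@@](C)(/C=C/c1ccc(O)cc1)CC/C=C(C)/C=C/C(=O)OCC` gives > 36600 nM, also a limit, so it has no number of its own. Among the measured compounds shown here, the series so far comes down to the limit of > 36600 nM in this assay, at which 3 of the 3 values shown sit.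

Compound 4 `C=C[C@@](C)(/C=C/c1ccc(O)cc1)CC/C=C(C)/C=C/C(=O)OCc1ccccc1` differs from compound 3 in one place: phenyl in place of methyl on a saturated chain carbon bound to an oxygen next to a carbonyl group. This is phenyl in place of methyl on a saturated chain carbon bound to an oxygen next to a carbonyl group, or ethoxycarbonyl to benzyloxycarbonyl.

The measured changes on this chain are a step that the two limits leave unreadable from compound 1 to compound 2, a step that the two limits leave unreadable from compound 1 to compound 3 and a step that the two limits leave unreadable from compound 2 to compound 3. None of them gives a size, and none touches the ethyl group itself. The expectation therefore rests on compound 3, whose limit is > 36600 nM.

The expected step is an at least 1.2-fold lower number from compound 3 to compound 4 (0.08 log units; that floor lies within the scatter), if anything toward smaller amounts, and another limit is quite likely. For compound 4 the estimate is 30000 nM, with an expected range of 12000 nM to 70000 nM.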

Compound 4, half-maximal effective concentration: > 36600 nM
Compound 4: only a limit was reported; the forecaster's own chance of this, stated with the estimate: 65%; middle value at least 1.2-fold (0.08 log units) from the limit.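

In this assay compound 4 gives > 36600 nM, which is a limit. Among the compounds shown here, with compound 3 also at a limit, no step between compound 3 and compound 4 can be read. The compounds shown leave open whether any change on this chain gives a readable number: the limit of > 36600 nM in this assay, at which 4 of the 4 values shown sit.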